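Sulfonyl aryl swap from dimethylphenyl to cyanophenyl

A few compounds are considered here, and "the series" means these few. Any claim that something is new, unique, unknown or untested is made for them only; others in the source may bear on it.

In an assay on isolated protein for displacement of a labelled ligand from metabotropic glutamate receptor 5 (Homo sapiens), with a stated time of 60 min, tested at 1 uM (a lower number here means less inhibition, a higher number more inhibition at the concentration tested (going by the name of the read-out)), compound 2 `Cc1cc(C)cc(S(=O)(=O)c2cnc3ccc(F)cc3c2N2CCC(C)CC2)c1` gives 83%. Compound 1 `Cc1cc(C)cc(S(=O)(=O)c2cnc3ccc(C)cc3c2N2CCC(C)CC2)c1` gives 80%, and the step of a number 3 percentage points higher from compound 1 to compound 2 (within the scatter) lies within the scatter. Compound 3 `Cc1cc(C)cc(S(=O)(=O)c2cnc3ccc(Cl)cc3c2N2CCC(C)CC2)c1` gives 49%; the steps of a number 31 percentage points lower from compound 1 to compound 3 (beyond the scatter) and a number 34 percentage points lower from compound 2 to compound 3 (beyond the scatter) are both large. Compound 4 `CC1CCN(c2c(S(=O)(=O)c3cccc(C#N)c3)cnc3ccc(F)cc23)CC1` carries the change (3-cyanophenyl in place of 3,5-dimethylphenyl on a sulfonyl sulfur). For the measured compounds named here, every measured step varies the substituent on an aromatic carbon of the shared core, whereas the change to compound 4 alters the group on the sulfonyl sulfur, so none of the measured steps bears on it. Going by the values given here, the only guide is that all three measured values sit in a broad band, so for compound 4 the expected value is near 60%, within 25% to 90%, an expected step of a number 23 percentage points lower from compound 2 to compound 4 (beyond the scatter) with wide uncertainty and no confident direction.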

Compound 4, a percentage reported as inhibition, at one concentration (the size of the read-out at that concentration, not a potency): 93%
Compound 4: the middle estimate sits 33 percentage points below what was measured, and the stated range ends below it.
By their numbers in this assay, from the lowest: compound 3; then compounds 1, 2 and 4 (each within the scatter of the next, the first and the last beyond it).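

On the sulfonyl sulfur, 3-cyanophenyl can take the place of 3,5-dimethylphenyl without a loss beyond the scatter: in this assay the change gives a number 10 percentage points higher from compound 2 to compound 4 (within the scatter). For the compounds shown here, this is the only view of this position, as the earlier steps all varied the substituent on an aromatic carbon of the shared core. Nothing at hand gives a reason for this result.

On these data alone, whether the swap holds with methyl or chloro in place of fluoro on the shared core stays open. So does the outcome with a pyridine ring or a primary amide on the sulfonyl sulfur.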